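A few compounds are considered here, and "the series" means these few. Any claim that something is new, unique, unknown or untested is made for them only; others in the source may bear on it.

Measured compounds and their values:

compound 1, `COc1ccc2[nH]c3c(c2c1)CCNC31CCN(Cc2ccc([N+](=O)[O-])cc2F)CC1`, 5900 nM
compound 2, `COc1ccc2[nH]c3c(c2c1)CCNC31CCN(Cc2cc(Cl)ccc2[N+](=O)[O-])CC1`, 7100 nM
compound 3, `COc1ccc2[nH]c3c(c2c1)CCNC31CCN(Cc2cc(F)cc(Cl)c2)CC1`, 2500 nM

All three share one core and differ only in the aromatic group carried on the saturated chain carbon bound to an amine nitrogen in a ring. In an assay on FRT cells for positive allosteric modulation of Cystic fibrosis transmembrane conductance regulator variant N1303K (Homo sapiens), in the presence of a further agent that is not named here (on this read-out higher numbers stand for an effect only at larger amounts of compound and lower numbers for an effect already at smaller amounts), compound 3 gives the lowest of the three numbers. Its nearest neighbour is compound 1, a step of a 2.4-fold lower number from compound 1 to compound 3 (0.37 log units; beyond the scatter), and the furthest is compound 2, a step of a 2.8-fold lower number from compound 2 to compound 3 (0.45 log units; beyond the scatter). Compound 1 and compound 2 sit close together, a 1.2-fold higher number from compound 1 to compound 2 (0.08 log units; within the scatter).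

Compound 4, `COc1ccc2[nH]c3c(c2c1)CCNC31CCN(Cc2ccccc2Cl)CC1`, has not yet been measured. Its change from compound 3 is 2-chlorophenyl in place of 3-chloro-5-fluorophenyl on a saturated chain carbon bound to an amine nitrogen in a ring. Among the measured compounds shown here, none of the measured steps removes a halogen or moves one without also removing a nitro group, so no step maps directly onto this change; the two steps into compound 3 only show that swapping one aromatic group for another here has moved the number by modest amounts. The expectation is therefore a small step in this assay, a 1.6-fold higher number from compound 3 to compound 4 (0.20 log units; within the scatter), which may not exceed the scatter. Compound 4 is estimated at 4000 nM, with a range from 1500 nM to 12000 nM.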

Compound 4, half-maximal effective concentration: 2200 nM
Beside the measured number, compound 4's estimate is 1.8-fold (0.26 log units) above it; the range from low to high includes it.
By their numbers in this assay, from the lowest: compounds 4 and 3 (each within the scatter of the next); then compounds 1 and 2 (each within the scatter of the next).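

In this assay, replacing 3-chloro-5-fluorophenyl with 2-chlorophenyl on a saturated chain carbon bound to an amine nitrogen in a ring gives a change within the scatter (a 1.1-fold lower number from compound 3 to compound 4 (0.06 log units; within the scatter)), so here the loss of fluorine and the different chlorine placement together leave no measurable mark. The steps from the two nitro-bearing compounds are both beyond the scatter (a 3.2-fold lower number from compound 2 to compound 4 (0.51 log units; beyond the scatter); a 2.7-fold lower number from compound 1 to compound 4 (0.43 log units; beyond the scatter)), which places compound 4 with compound 3 and gives two groups among these four compounds: the two with only halogen on the phenyl ring have lower numbers than the two that also carry a nitro group, and none of the four goes against this. Nothing here gives a measured reason for these differences.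

Because each nitro-bearing group also differs from the others in its halogen, the effect of the nitro group alone cannot be separated from that of the halogens. Also open, going by these compounds, is how this position would respond to a phenyl ring with no halogen, to a phenyl ring carrying an amine or a carboxylic acid, or to a longer chain in place of the benzyl link.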